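This account rests on a few compounds, and the source may have more. Where it says the series, first, only, none or still open, it means among the compounds named here.

Of the compounds shown here, two that share one core have been measured so far. Compound 1 `Cc1cc(O)c(C2=NN(c3ccc(S(N)(=O)=O)cc3)C(c3ccccc3Cl)C2)cc1Cl` gives 2030 nM in a functional assay on HOP-62 cells (Homo sapiens) for antiproliferative activity, with a stated time of 48 h; on this read-out lower numbers stand for stronger inhibition of growth and higher numbers for weaker inhibition of growth. Compound 2 `Cc1cc(O)c(C2=NN(c3ccc(S(N)(=O)=O)cc3)C(/C=C/c3ccccc3)C2)cc1Cl` gives 3940 nM in this assay. Within the data shown here, compound 2 stands beside compound 1, the only other compound measured, and the two numbers lie within the scatter of each other: the step from a 1.9-fold higher number from compound 1 to compound 2 (0.29 log units; within the scatter) counts as no real change.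

Compound 3 `COc1ccc(C2CC(c3cc(Cl)c(C)cc3O)=NN2c2ccc(S(N)(=O)=O)cc2)c(OC)c1OC` has not yet been measured. It differs from compound 2 in one place, (2,3,4-trimethoxyphenyl in place of 2-phenylethenyl on a saturated ring carbon). Among the measured compounds shown here, the only measured step that speaks to this spot on the core is the one from a 1.9-fold higher number from compound 1 to compound 2 (0.29 log units; within the scatter), which swapped one group on the same saturated ring carbon for another and stayed within the scatter. For the measured compounds named here, the trimethoxyphenyl group is a different kind of replacement, and no measured pair shows its effect, so the expectation rests on that single step and is loose.

Compound 3 is therefore expected to give about 3000 nM in this assay, somewhere between 1000 nM and 9000 nM, an estimated step from a 1.3-fold lower number from compound 2 to compound 3 (0.12 log units; within the scatter) that need not rise beyond the scatter.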

Compound 3, concentration for 50% growth inhibition: 2100 nM
Compound 3: the middle estimate sits 1.4-fold (0.15 log units) above what was measured; low and high end bracket the measured number.
By their numbers in this assay, from the lowest: compounds 1, 3 and 2 (each within the scatter of the next).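

In this assay, putting 2,3,4-trimethoxyphenyl, with 12 heavy atoms and 3 hydrogen-bond acceptors, in place of 2-phenylethenyl, with 8 heavy atoms and 0 hydrogen-bond acceptors, gives a 1.9-fold lower number from compound 2 to compound 3 (0.27 log units; within the scatter), so the added heavy atoms and acceptors on this saturated ring carbon do not move the number beyond the scatter. Compared with the 2-chlorophenyl group, the same trimethoxyphenyl group gives a 1.0-fold higher number from compound 1 to compound 3 (0.01 log units; within the scatter), which means that all three groups on this carbon, next to the ring nitrogen, now lie within the scatter of one another, and the position shows no measurable preference among them. No supporting measurement is available to explain why these numbers stay so close.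

Going by these compounds, all three groups bring a six-membered aromatic ring of carbon only or, for 2-phenylethenyl, that ring on a short chain, so it remains open whether an amine, a carboxylic acid or a plain saturated alkyl chain on this carbon would give a step beyond the scatter. The compounds shown also leave open how much the 4-sulfamoylphenyl group and the 5-chloro-2-hydroxy-4-methylphenyl group contribute, as both stay the same throughout.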